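Trimming the amide substituent from methylbenzyl to propyl

The source may report more compounds than this note shows. Statements on the series, on what has been measured and on what is new or still open speak of the compounds shown alone.

Compound 2 `C=CC1=C(C(=O)NCc2ccc(C)cc2)C(c2ccc(OC)cc2)OC1` carries a 4-methylbenzyl group on its amide nitrogen and a methoxy group on its aromatic ring. In a functional assay on QGY7701 cells (Homo sapiens) for cytotoxicity, read by MTT assay, with a stated time of 24 h (on this read-out higher numbers stand for weaker inhibition and lower numbers for stronger inhibition), compound 2 gives 43100 nM, the lowest number shown, though compound 3 sits within the scatter of it. Compound 3 `C=CC1=C(C(=O)NCc2ccc(C)cc2)C(c2ccc(F)cc2)OC1` has fluoro in place of methoxy on an aromatic carbon, and in this assay compound 3 gives 62100 nM; the step of a 1.4-fold higher number from compound 2 to compound 3 (0.16 log units; within the scatter) is within the scatter. Compound 1 `C=CC1=C(C(=O)NC2CCCCC2)C(c2ccc(OC)cc2)OC1` carries cyclohexyl instead of 4-methylbenzyl on the amide nitrogen. For compound 1 this assay reports only a limit, > 100000 nM, namely (the limit of > 100000 nM in this assay, at which 1 of the 3 values shown sits). Among the measured compounds shown here, the step of an at least 2.3-fold lower number from compound 1 to compound 2 (0.36 log units; beyond the scatter) is the one clear change among the measured compounds.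

Compound 4 `C=CC1=C(C(=O)NCCC)C(c2ccc(OC)cc2)OC1` is not yet measured. It differs from compound 2 by ethyl in place of 4-methylphenyl on a saturated chain carbon bound to an amide-type nitrogen. For the measured compounds named here, only the step from compound 1 to compound 2 touches this position, and there the number fell when an aromatic ring arrived; removing that ring again is therefore expected to raise the number, perhaps toward the limit. Compound 4 is estimated at 80000 nM, between 30000 nM and 200000 nM. That amounts to an expected 1.9-fold higher number from compound 2 to compound 4 (0.27 log units; within the scatter).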

Compound 4, half-maximal inhibitory concentration: > 100000 nM
Compound 4: no number, only a limit; the forecaster's own chance of this, stated with the estimate: 35%; middle value at least 1.2-fold (0.09 log units) from the limit.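

The change from 4-methylbenzyl to propyl gives an at least 2.3-fold higher number from compound 2 to compound 4 (0.36 log units; beyond the scatter) in this assay. Before this, the only comparison at this position was with cyclohexyl, so an open chain and a saturated ring now both fall short of 4-methylbenzyl. Among the compounds shown, only compound 2 and compound 3, which both carry 4-methylbenzyl, give actual numbers, while compound 1 and compound 4 give only a limit, so the step between those two cannot be read: the limit of > 100000 nM in this assay, at which 2 of the 4 values shown sit.

On these data alone, it remains open whether the aromatic ring itself matters or whether a longer chain, such as hexyl, could serve as well. Also open, as far as these compounds go, is whether plain benzyl, without the methyl group, would keep a measurable number, and what an amine on the propyl chain would do.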